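The source may hold more compounds than are shown below. What is called first, only, known or untested is meant among the compounds shown, and "the series" means these compounds.

Measured so far in an assay on CHO cells for displacement of a labelled ligand from adenosine receptor A3 (Homo sapiens), read by scintillation counting, with a stated time of 120 min, tested at 1 uM; a lower number here means less inhibition, a higher number more inhibition at the concentration tested (going by the name of the read-out):
compound 1, `Cc1nc2sc(-c3ccco3)nc2c(=O)[nH]1`: 20%
compound 2, `Cc1nc2sc(Nc3ccccc3)nc2c(=O)[nH]1`: 45%

Compound 2 gives the higher of the two numbers in this assay, and the gap to compound 1 lies beyond the usual scatter. Among the measured compounds shown here, no step between these two is worked out, so only the two values themselves are taken as read. Compound 3, `COc1ccc(Nc2nc3c(=O)[nH]c(C)nc3s2)cc1`, differs from compound 2 by methoxy in place of hydrogen on an aromatic carbon. For the measured compounds named here, no measured pair shows the effect of this change in this assay, so the size of the step is open. Given the value of compound 2 in this assay, 45%, compound 3 is expected to stay near that level, with a step of a number 3 percentage points higher from compound 2 to compound 3 (within the scatter) that is not expected to go beyond the scatter. Compound 3 is estimated at 48%, within a range from 28% to 68%.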

Compound 3, a percentage reported as inhibition, at one concentration (the size of the read-out at that concentration, not a potency): 36%
Estimate against measurement, compound 3: 12 percentage points above; low and high end bracket the measured number.
By their numbers in this assay, from the lowest: compound 1; then compounds 3 and 2 (each within the scatter of the next).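

In this assay, methoxy in place of hydrogen on an aromatic carbon, para to a large group on the six-membered aromatic ring, gives a number 9 percentage points lower from compound 2 to compound 3 (within the scatter). Among the compounds shown here, this is the first measured pair that differs in one place, and it shows that the number at this position stays within the scatter when methoxy enters. The two values therefore cannot be ranked, and the number in this read-out stays level when this one group enters at this ring position. No available evidence bears on this result or accounts for the size of the step.

A hydroxyl, an amine, a carboxylic acid or a longer chain at the same position could still move the number beyond the scatter. On these data alone, how methoxy behaves at other carbons of this ring also remains open.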